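A few compounds are considered here, and "the series" means these few. Any claim that something is new, unique, unknown or untested is made for them only; others in the source may bear on it.

Measured compounds in an ADME assay on RAW264.7 cells (Mus musculus) for cytotoxicity, read by MTT assay, with a stated time of 24 h; on this read-out lower numbers stand for higher toxicity in this test and higher numbers for lower toxicity in this test:
- compound 1 `COc1ccccc1C(=O)Nc1ccc(Cl)cc1F` gives > 40000 nM
- compound 2 `O=C(Nc1ccc(Cl)cc1F)c1ccccc1OCc1ccc(F)cc1F` gives > 40000 nM
- compound 3 `COc1ccc(C(=O)Nc2ccc(Cl)cc2F)c(OC)c1` gives 13600 nM

The value of compound 1 is a limit of this assay, not a number. The value of compound 2 is likewise a limit. Only compound 3 gives a readable number, and the two limits sit at the limit of > 40000 nM in this assay, at which 2 of the 3 values shown sit.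

Compound 3 differs from compound 1 in its core: methoxy in place of hydrogen on an aromatic carbon. This change gives an at least 2.9-fold lower number from compound 1 to compound 3 (0.46 log units; beyond the scatter).

Compound 2 differs from compound 1 by 2,4-difluorophenyl in place of hydrogen on a saturated chain carbon bound to an oxygen on an aromatic ring. Here the step is a step that the two limits leave unreadable from compound 1 to compound 2, since both values are limits.

Compound 4 `COc1ccc(C(=O)Nc2ccc(Cl)cc2F)c(OCc2ccc(F)cc2F)c1` is not yet measured in this assay. It differs from compound 3 by 2,4-difluorophenyl in place of hydrogen on a saturated chain carbon bound to an oxygen on an aromatic ring. The place of this change reads the same, word for word, as in the step from compound 1 to compound 2, so it is the same change, made on the core of compound 3 rather than that of compound 1.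

The earlier instance of this change is unreadable. No direction or size can be taken from it. The expectation therefore rests on compound 3 alone, whose value is 13600 nM. Compound 4 is expected to show a step of a 1.1-fold lower number from compound 3 to compound 4 (0.05 log units; within the scatter) in this assay, with wide uncertainty either way. The estimate for compound 4 is 12000 nM, with an expected range from 3500 nM to 40000 nM.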

Compound 4, half-maximal cytotoxic concentration: > 40000 nM
Compound 4: a limit, no number; the forecaster's own chance of this, stated with the estimate: 30%; middle value at least 3.3-fold (0.52 log units) away from the limit.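

In this assay, 2,4-difluorophenyl in place of hydrogen on a saturated chain carbon bound to an oxygen on an aromatic ring gives an at least 2.9-fold higher number from compound 3 to compound 4 (0.46 log units; beyond the scatter), so on the core of compound 3 this change moves the read-out towards lower toxicity in this test. Compound 4 gives > 40000 nM, which is a limit and not a number. The same change on the core of compound 1 cannot be read, nor can the methoxy step from compound 2 to compound 4, so the series shows this change on one core only and does not show whether its effect carries from one core to another, with most values resting at the same limit: the limit of > 40000 nM in this assay, at which 3 of the 4 values shown sit.

Within the data shown here, with compound 3 as the only readable number, at 13600 nM, it stays open how far the change on its core really reaches and whether the 2,4-difluorophenyl group itself is needed for the step. Also open, from the compounds shown here alone, is how this read-out would respond at the same place to an unsubstituted benzyl, a longer chain, a tertiary amine or a carboxylic acid.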